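Butoxy in place of benzyl on an aminoindazole urea

The source may hold more compounds than are shown below. What is called first, only, known or untested is meant among the compounds shown, and "the series" means these compounds.

Measured compounds:
compound 1, `Nc1nn(C(=O)Nc2ccc(Cc3ccccc3)cc2)c2ccccc12`: 1690 nM
compound 2, `COc1ccccc1NC(=O)n1nc(N)c2ccccc21`: > 100000 nM

In a functional assay on ACHN cells (Homo sapiens) for inhibition, read by sulforhodamine B assay, with a stated time of 48 h (on this read-out higher numbers stand for weaker inhibition of growth and lower numbers for stronger inhibition of growth), compound 1 gives 1690 nM, and this is the only numerical result in the set. Compound 2 sits at the limit of > 100000 nM in this assay, at which 1 of the 2 values shown sits, so its result is a limit of the assay rather than a number. Within the data shown here, compound 1 therefore stands alone as the single measured number, with no measured step between two numbers to set a scale for the effect of any change.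

Compound 3, `CCCCOc1ccc(NC(=O)n2nc(N)c3ccccc32)cc1`, differs from compound 1 by butoxy in place of benzyl on an aromatic carbon. Among the measured compounds shown here, no measured pair shows what this kind of change does in this assay, so the expectation rests on the position of compound 1 alone. The group that leaves carries a ring and the group that enters carries one hydrogen-bond acceptor and no ring; beyond that the data give no guidance. Compound 3 is expected to remain in the same region as compound 1, with the step of a 2.1-fold higher number from compound 1 to compound 3 (0.32 log units; beyond the scatter) estimated as a small loss, close to the scatter. The estimate for compound 3 is 3500 nM, within a range of 900 nM to 15000 nM.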

Compound 3, concentration for 50% growth inhibition: 22800 nM
Beside the measured number, compound 3's estimate is 6.5-fold (0.81 log units) below it; the whole stated range lies below it.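

In this assay, butoxy in place of benzyl on an aromatic carbon, para to a large group, gives a 13-fold higher number from compound 1 to compound 3 (1.13 log units; beyond the scatter). Among these compounds, this is the first measured step in the set, and it shows that growth inhibition at this position depends strongly on which of these two groups is present. The change still leaves compound 3 with a measured number rather than a limit of the assay, but nothing shown here accounts for the size of the step.

Going by these compounds, what stays open is which part of the change carries the step, since the benzyl group that leaves has a six-membered aromatic ring and the butoxy group that enters has no ring but has one hydrogen-bond acceptor, and this single pair alters both features at once. A phenoxy group, with an oxygen and a ring, and a pentyl chain, with neither, would bear on that question, as would a shorter chain such as ethoxy on whether the length of the butoxy chain matters.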